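Replacing the Phenyl on the Urea Nitrogen with a Dimethylcarbamoylmethyl Chain

The compounds below may be only part of what the source reports. "The series", "measured", "known", "first", "only" and "open" are said of these compounds alone.

Measured so far:
Compound 1 `Cc1cc(C(=O)N2CCCCc3ccccc32)ccc1CNC(=O)Nc1c(F)cccc1F` — 2.1 nM
Compound 2 `Cc1cc(C(=O)N2CCCCc3ccccc32)ccc1CNC(=O)Nc1ccccc1` — 130 nM
Not yet measured:
Compound 3 `Cc1cc(C(=O)N2CCCCc3ccccc32)ccc1CNC(=O)NCC(=O)N(C)C`

In a functional assay on HEK293 cells for agonist activity at Vasopressin V2 receptor (Homo sapiens), read by a luciferase reporter and cAMP accumulation (on this read-out higher numbers stand for an effect only at larger amounts of compound and lower numbers for an effect already at smaller amounts), compound 1 gives 2.1 nM and compound 2 gives 130 nM. Compound 2 therefore stands at the higher of the two numbers. Among the measured compounds shown here, the only step known so far is a 62-fold higher number from compound 1 to compound 2 (1.79 log units; beyond the scatter), a large step that comes from putting a plain phenyl in place of the 2,6-difluorophenyl on an amide-type nitrogen. Compound 3 changes that same place once more: (dimethylcarbamoyl)methyl in place of phenyl on an amide-type nitrogen. For the measured compounds named here, no measured step covers a move from an aromatic ring to an open chain of this kind, so the guidance is indirect: the one known change at this position was large and ran toward higher numbers, and taking the ring away entirely is a bigger change than taking away two fluorines. A further move toward higher numbers is therefore expected in this assay, with wide uncertainty, so compound 3 is estimated at 1200 nM (range 200 nM to 8000 nM), which corresponds to an expected step of a 9.2-fold higher number from compound 2 to compound 3 (0.97 log units; beyond the scatter).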

Compound 3, half-maximal effective concentration: 58 nM
Compound 3: the middle estimate sits 21-fold (1.32 log units) above what was measured; the measured number lies below the stated range.
By their numbers in this assay, from the lowest: compound 1; then compound 3; then compound 2.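

In this assay, an aromatic ring on this amide-type nitrogen proves not to be required for activity: the ring-free (dimethylcarbamoyl)methyl chain gives a 2.2-fold lower number from compound 2 to compound 3 (0.35 log units; beyond the scatter), a modest step but one beyond the scatter. An open chain with the same heavy-atom count as phenyl can therefore do slightly better than the unsubstituted ring, so the large loss seen on removing the two fluorines does not mark the limit of what this position tolerates. Even so, the chain does not come close to the best group here, as replacing 2,6-difluorophenyl with it gives a 28-fold higher number from compound 1 to compound 3 (1.44 log units; beyond the scatter), and no measurement at hand explains why these three groups rank as they do.

The compounds shown leave open how much of this activity depends on the dimethylcarbamoyl end of the chain, which a carboxylic acid, an amine or a longer chain carrying the same dimethylamide would help to test. They also leave open whether a phenyl bearing a single fluorine would fall closer to the 2,6-difluorophenyl group or to the plain phenyl.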